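Swapping 2-cyanophenyl for 3-sulfamoylphenyl after compound 3

This account rests on a few compounds, and the source may have more. Where it says the series, first, only, none or still open, it means among the compounds named here.

In an ADME assay on MT4 cells (Homo sapiens) for cytotoxicity, read by MTT assay, with a stated time of 5 days (on this read-out higher numbers stand for lower toxicity in this test and lower numbers for higher toxicity in this test), compound 1 `COc1cc2nc([S+]([O-])CC(=O)Nc3ccccc3[N+](=O)[O-])nc(Nc3c(Cl)cc(/C=C/C#N)cc3Cl)c2cc1OC` gives > 199000 nM as a limit of the assay, not a number. Compound 3 `COc1cc2nc([S+]([O-])CC(=O)Nc3ccccc3C#N)nc(Nc3c(Cl)cc(/C=C/C#N)cc3Cl)c2cc1OC` gives > 206000 nM as a limit too. Compound 2 `COc1cc2nc([S+]([O-])CC(=O)Nc3cccc(Cl)c3)nc(Nc3c(Cl)cc(/C=C/C#N)cc3Cl)c2cc1OC` gives 68900 nM as a true number. Compound 4 `COc1cc2nc([S+]([O-])CC(=O)Nc3cccc(S(N)(=O)=O)c3)nc(Nc3c(Cl)cc(/C=C/C#N)cc3Cl)c2cc1OC` carries 3-sulfamoylphenyl in place of 2-cyanophenyl on an amide-type nitrogen. Swaps of this same group gave an at least 2.8-fold lower number from compound 1 to compound 2 (0.46 log units; beyond the scatter) and also an at least 2.9-fold higher number from compound 2 to compound 3 (0.47 log units; beyond the scatter) as measured steps. The 3-chlorophenyl of compound 2 with 68900 nM is the nearest match by name to 3-sulfamoylphenyl, so a lower number is expected. The expected modest move is an at least 2.0-fold lower number from compound 3 to compound 4 (0.31 log units; beyond the scatter) in this assay for this swap. Compound 4 is estimated at 100000 nM (range 40000 nM to 250000 nM).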

Compound 4, half-maximal cytotoxic concentration: 67800 nM
Compound 4: middle estimate off by 1.5-fold (0.17 log units), on the high side; the measured number falls inside the stated range.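

In this assay, the change from chloro to sulfamoyl gives a 1.0-fold lower number from compound 2 to compound 4 (0.01 log units; within the scatter), so these two different groups read alike here. Moving away from the other two groups gives an at least 3.0-fold lower number from compound 3 to compound 4 (0.48 log units; beyond the scatter) and an at least 2.9-fold lower number from compound 1 to compound 4 (0.46 log units; beyond the scatter); among these four compounds, 3-chlorophenyl and 3-sulfamoylphenyl give true numbers, while 2-cyanophenyl and 2-nitrophenyl give limits. Compound 3 stands at a limit, not a number, so the full size of its step stays unknown: the limit of > 206000 nM in this assay, at which 1 of the 4 values shown sits.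

Going by these compounds, what remains open is whether the place on the ring or the group itself sets this divide. A 2-sulfamoylphenyl, or a phenyl carrying a carboxylic acid or an amine, would test it.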